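A few compounds are considered here, and "the series" means these few. Any claim that something is new, unique, unknown or untested is made for them only; others in the source may bear on it.

Working notes on the series, all read in a functional assay on HCT-116 cells (Homo sapiens) for inhibition, read by MTT assay, with a stated time of 48 h; a higher number here means a weaker inhibitor, a lower number a stronger inhibitor. Compound 1 (`CCCCC(=O)N(Cc1ccc(OC)c(O)c1)c1cc(OC)c(OC)c(OC)c1`) gives 170 nM as a half-maximal inhibitory concentration, compound 2 (`COCC(=O)N(Cc1ccc(OC)c(O)c1)c1cc(OC)c(OC)c(OC)c1`) gives 230 nM and compound 3 (`COc1ccc(CN(C(=O)C(C)Br)c2cc(OC)c(OC)c(OC)c2)cc1O`) gives 140 nM on the same read-out. Compound 3 cannot be separated from the other two: the steps are a 1.2-fold lower number from compound 1 to compound 3 (0.08 log units; within the scatter) and a 1.6-fold lower number from compound 2 to compound 3 (0.22 log units; within the scatter) and both stay within the scatter.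

Compound 4 (`C#CC(=O)N(Cc1ccc(OC)c(O)c1)c1cc(OC)c(OC)c(OC)c1`) carries ethynyl in place of 1-bromoethyl on a carbonyl carbon. The relevant evidence is the set of measured changes at this same carbonyl carbon, which also include a 1.4-fold higher number from compound 1 to compound 2 (0.13 log units; within the scatter) and stay within the scatter. Within the data shown here, no measured compound carries ethynyl, so this is an extrapolation from three groups only. No step beyond the scatter is expected, and the expected move is a 1.3-fold higher number from compound 3 to compound 4 (0.11 log units; within the scatter) as estimated. For compound 4 the estimated value is 180 nM with an expected range of 60 nM to 550 nM for the measurement.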

Compound 4, half-maximal inhibitory concentration: 310 nM
Estimate against measurement, compound 4: 1.7-fold (0.24 log units) below; measured number inside the range.
By their numbers in this assay, from the lowest: compounds 3, 1, 2 and 4 (each within the scatter of the next, the first and the last beyond it).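

In this assay, among these compounds, the change to ethynyl gives the first step at this carbonyl carbon that lies beyond the scatter, a 2.2-fold higher number from compound 3 to compound 4 (0.35 log units; beyond the scatter), and it is a modest one. The same change does not separate ethynyl from the other two groups, with a 1.3-fold higher number from compound 2 to compound 4 (0.13 log units; within the scatter) and a 1.8-fold higher number from compound 1 to compound 4 (0.26 log units; within the scatter) both within the scatter, so only 1-bromoethyl and ethynyl are told apart here. Nothing among the data available accounts for this step.

Whether the step goes with the entering triple bond or with the leaving 1-bromoethyl stays open, as the compounds shown include neither a 1-chloroethyl nor a propenyl group at this carbonyl carbon to divide the two. Going by these compounds, how an aminomethyl group or a carboxylic acid chain in the same place would read also remains open.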